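Moving the Ether Group to a New Spot on the Ring

This account rests on a few compounds, and the source may have more. Where it says the series, first, only, none or still open, it means among the compounds named here.

Three compounds share one core and differ only in the group on the outer phenyl ring. In a functional assay on CCRF-CEM cells (Homo sapiens) for inhibition, read by cell counting, with a stated time of 3 days (a higher number here means a weaker inhibitor, a lower number a stronger inhibitor), compound 1 `C=C(Br)C(=O)Nc1cccc(-c2cn3nc(-c4ccc(CC)cc4)sc3n2)c1` gives 3400 nM, compound 2 `C=C(Br)C(=O)Nc1cccc(-c2cn3nc(-c4ccc(F)cc4)sc3n2)c1` gives 830 nM, and compound 3 `C=C(Br)C(=O)Nc1cccc(-c2cn3nc(-c4ccc(OCC)cc4)sc3n2)c1` gives 1400 nM. Compound 3 thus stands second highest of the three: the step of a 1.7-fold higher number from compound 2 to compound 3 (0.23 log units; within the scatter) stays within the scatter, while the step of a 2.4-fold lower number from compound 1 to compound 3 (0.39 log units; beyond the scatter) lies beyond it. Compound 4 `C=C(Br)C(=O)Nc1cccc(-c2cn3nc(-c4cccc(OC)c4)sc3n2)c1` carries 3-methoxyphenyl in place of 4-ethoxyphenyl on an aromatic carbon. Within the data shown here, every measured step, including a 4.1-fold lower number from compound 1 to compound 2 (0.61 log units; beyond the scatter), swapped one group for another without changing where it sits on that ring, so no measured step bears directly on this change. The expected step of a 1.1-fold higher number from compound 3 to compound 4 (0.03 log units; within the scatter) is therefore one that stays within the scatter. Compound 4 is estimated at 1500 nM, ranging from 500 nM to 4500 nM.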

Compound 4, half-maximal inhibitory concentration: 1200 nM
For compound 4 the middle estimate is 1.3-fold (0.10 log units) above the measured one; the measured number falls inside the stated range.
By their numbers in this assay, from the lowest: compounds 2, 4 and 3 (each within the scatter of the next); then compound 1.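

In this assay, replacing 4-ethoxyphenyl with 3-methoxyphenyl gives a 1.2-fold lower number from compound 3 to compound 4 (0.07 log units; within the scatter), so changing both the place of the ether and its chain length leaves the number within the scatter. The same holds for the change from 4-fluorophenyl, which gives a 1.4-fold higher number from compound 2 to compound 4 (0.16 log units; within the scatter), while the change from 4-ethylphenyl gives a 2.8-fold lower number from compound 1 to compound 4 (0.45 log units; beyond the scatter), a step beyond the scatter. No supporting evidence accompanies these results.

On these data alone, because place and chain changed together, their separate contributions remain open; 4-methoxyphenyl or 3-ethoxyphenyl would separate them. As far as these compounds go, how an amine or a carboxylic acid on this outer ring would read also remains open.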